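The source may hold more compounds than are shown below. What is called first, only, known or untested is meant among the compounds shown, and "the series" means these compounds.

Measured so far in an assay on HEK293 cells for agonist activity at transient receptor potential cation channel subfamily M member 8 (Homo sapiens), read by fluorescence and calcium flux, with a stated time of 15 min; a higher number here means that more compound is needed for the effect, a lower number that less compound is needed:

compound 1, `CCN(Cc1cccs1)C(=O)COc1ccc(C(=O)O)cc1`: "not active" (no number reported)
compound 2, `Cc1ccc(OCC(=O)N(Cc2cccs2)c2ccnn2C)cc1`: 422 nM
compound 3, `CCN(Cc1cc[nH]c1)C(=O)COc1ccc(C)cc1`: 21800 nM

Compound 1 gives no number in this assay, only the statement that it is not active. Of the two compounds with a number, compound 2 has the lower one; compound 3 stands well higher, beyond the scatter. Compound 2 therefore marks the present low point of the series.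

The next compound, compound 4, `Cc1ccc(OCC(=O)N(Cc2cccs2)c2ccncc2)cc1`, differs from compound 2 in a single place:

pyridin-4-yl in place of 1-methyl-1H-pyrazol-5-yl on an amide-type nitrogen

For the measured compounds named here, no pair of measured compounds differs in only one place, so no step of the same kind has been observed. The series gives one pairing that tells a change on the amide-type nitrogen and at the aromatic ring pattern together, but nothing that isolates a swap of one aromatic ring for another on that nitrogen. The expectation is that this exchange alters the number only moderately, in the direction of a somewhat higher value, yet not with confidence beyond the scatter.

For compound 4 the expected step is a 2.1-fold higher number from compound 2 to compound 4 (0.33 log units; beyond the scatter). Compound 4 is estimated at 900 nM, within a range from 250 nM to 4000 nM.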

Compound 4, half-maximal effective concentration: 52 nM
Compound 4: middle estimate off by 17-fold (1.24 log units), on the high side; measured number outside the range, below it.
By their numbers in this assay, from the lowest: compound 4; then compound 2; then compound 3.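

For the compounds shown here, on the amide-type nitrogen whose other neighbours are a carbonyl carbon and a saturated chain carbon, the choice of aromatic ring clearly matters in this assay: pyridin-4-yl in place of 1-methyl-1H-pyrazol-5-yl gives an 8.1-fold lower number from compound 2 to compound 4 (0.91 log units; beyond the scatter) and is the first step that isolates a single place. The two groups have equal heavy-atom counts but differ in ring size, in hetero atoms and in hydrogen-bond acceptors, and this one step cannot separate those differences. Nothing measured in the data shown bears on the reason for the step.

From the compounds shown here alone, it remains open whether the lower number belongs to the six-membered ring as such or to the location of its ring nitrogen, a question that phenyl, pyridin-3-yl and pyridin-2-yl on the same nitrogen would address. Going by these compounds, compound 1 and compound 3 each differ from compound 4 in more than one place, so how a saturated amine or a longer chain in place of the ring on that nitrogen would read also stays open.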